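Methoxy additions on the ester group: outlook for compound 3

The compounds below may be only part of what the source reports. "The series", "measured", "known", "first", "only" and "open" are said of these compounds alone.

Measured so far:
compound 1 `COC(=O)/C(=C\c1ccc(OC(=O)c2ccccc2)cc1)Sc1ccnc2cc(Cl)ccc12` — in a functional assay on Jurkat E6.1 cells (Homo sapiens) for cytotoxicity, read by MTT assay, with a stated time of 24 h (a higher number here means a weaker inhibitor, a lower number a stronger inhibitor), compound 1 gives 35700 nM.
compound 2 `COC(=O)/C(=C\c1ccc(OC(=O)c2ccc(OC)cc2OC)cc1)Sc1ccnc2cc(Cl)ccc12` — in this assay compound 2 gives 10200 nM.
compound 3 `COC(=O)/C(=C\c1ccc(OC(=O)c2cc(OC)c(OC)cc2OC)cc1)Sc1ccnc2cc(Cl)ccc12` — not yet measured in this assay.

Among the measured compounds shown here, compound 2 has the lowest of the two numbers in hand; its only neighbour is compound 1, and the step of a 3.5-fold lower number from compound 1 to compound 2 (0.54 log units; beyond the scatter) came with 2,4-dimethoxyphenyl in place of phenyl on a carbonyl carbon. Compound 3 carries the same change one step further: methoxy in place of hydrogen on an aromatic carbon.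

For the measured compounds named here, the one measured step that bears on this is the step from compound 1 to compound 2, a modest lowering beyond the scatter when two methoxy groups entered. A third methoxy on the same ring is a smaller change than that; expected for compound 3 is a step of a 1.5-fold lower number from compound 2 to compound 3 (0.16 log units; within the scatter), most likely a small further lowering, possibly none beyond the scatter. Compound 3 is estimated at 7000 nM, within 2500 nM to 20000 nM.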

Compound 3, half-maximal inhibitory concentration: 9650 nM
The estimate for compound 3 lay 1.4-fold (0.14 log units) below the measured number; the range from low to high includes it.
By their numbers in this assay, from the lowest: compounds 3 and 2 (each within the scatter of the next); then compound 1.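

In this assay, methoxy in place of hydrogen on an aromatic carbon, ortho to one methoxy group and para to another, leaves compound 2 and compound 3 within the scatter of each other (a 1.1-fold lower number from compound 2 to compound 3 (0.02 log units; within the scatter)), so this position shows no readable response to this change. Set against compound 1, compound 3 shows a modest step beyond the scatter (a 3.7-fold lower number from compound 1 to compound 3 (0.57 log units; beyond the scatter)). 2,4-dimethoxyphenyl already gives a step of similar size, and the added methoxy contributes no separable part of the distance from compound 1 on these numbers. Nothing available explains why the added methoxy leaves the number within the scatter.

Still open, on these data alone, is whether a single methoxy on the phenyl ring would be enough for the step away from compound 1, and whether the two methoxy groups of compound 2 contribute equally to it. Also open, as far as these compounds go, is what a hydroxyl, an amine, a carboxylic acid or a longer chain such as ethoxy would give at the position that takes the new methoxy in compound 3.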